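This account rests on a few compounds, and the source may have more. Where it says the series, first, only, none or still open, it means among the compounds named here.

Compound 1 `COc1cc(OC)c(OC)cc1/C=C/C(=O)c1ccc([N+](=O)[O-])cc1`: in a functional assay on HeLa cells (Homo sapiens) for inhibition, read by MTT assay, with a stated time of 72 h (a higher number here means a weaker inhibitor, a lower number a stronger inhibitor), compound 1 gives > 150000 nM, a limit of the assay.
Compound 2 `COc1ccc(C(=O)/C=C/c2cc(OC)c(OC)cc2OC)cc1`: in this assay compound 2 gives 37600 nM.
Compound 3 `COc1cc(OC)c(OC)cc1/C=C/C(=O)c1ccccc1`: in this assay compound 3 gives > 150000 nM, a limit of the assay.

Compound 3 thus stands only at a limit, one of the two values that sit at the limit of > 150000 nM in this assay, at which 2 of the 3 values shown sit. Compound 4 `COc1cc(OC)c(OC)cc1/C=C/C(=O)c1ccc(Br)cc1` differs from compound 3 by bromo in place of hydrogen on an aromatic carbon. Within the data shown here, no measured step places a bromo at that position. The steps that touch the position are an at least 3.9-fold lower number from compound 1 to compound 2 (0.60 log units; beyond the scatter) and an at least 3.9-fold higher number from compound 2 to compound 3 (0.60 log units; beyond the scatter), whereas a step that the two limits leave unreadable from compound 1 to compound 3. A methoxy there yields a number; a nitro and a hydrogen there each yield a limit, so the bromo is an open question. Compound 4 is expected to stay close to the limit, an at least 1.2-fold lower number from compound 3 to compound 4 (0.09 log units; that floor lies within the scatter). Compound 4 is estimated at 120000 nM, between 25000 nM and 300000 nM.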

Compound 4, half-maximal inhibitory concentration: 31700 nM
Compound 4: middle estimate off by 3.8-fold (0.58 log units), on the high side; low and high end bracket the measured number.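

Among these compounds, on the aromatic carbon para to a large group, methoxy is no longer the only group that gives a readable number in this assay: bromo in place of hydrogen gives an at least 4.7-fold lower number from compound 3 to compound 4 (0.67 log units; beyond the scatter), and bromo in place of nitro gives an at least 4.7-fold lower number from compound 1 to compound 4 (0.67 log units; beyond the scatter). Bromo and methoxy cannot be told apart there, with a 1.2-fold lower number from compound 2 to compound 4 (0.07 log units; within the scatter). Compound 1 and compound 3 remain limits: the limit of > 150000 nM in this assay, at which 2 of the 4 values shown sit.

On these data alone, whether a chloro or an amine at this position also gives a readable number stays open. The compounds shown also do not tell what separates bromo and methoxy from hydrogen and nitro.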